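The source may report more compounds than this note shows. Statements on the series, on what has been measured and on what is new or still open speak of the compounds shown alone.

Notes on a small set of compounds run in an assay on isolated protein for binding affinity to Equilibrative nucleoside transporter 1 (Homo sapiens); a lower number here means a stronger inhibitor, a higher number a weaker inhibitor. Compound 1 `CCCC(C)n1cnc2c(SCc3ccccn3)nc(N)nc21` gives 41700 nM. Compound 2 `Cc1cccc(CSc2nc(N)nc3c2ncn3[C@@H]2O[C@H](CO)[C@@H](O)[C@H]2O)n1` gives 11500000 nM. Compound 3 `OC[C@H]1O[C@@H](n2cnc3c(CSc4ccc(Cl)c(Cl)c4)ncnc32)[C@H](O)[C@@H]1O` gives 224 nM, the lowest number of the three; of the other two, compound 1 is the nearest and compound 2 the furthest, and both gaps lie beyond the usual scatter of the assay. Going by the values given here, no two of these three compounds differ in only one place, so no single step has been read from the measured set.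

Compound 4 `CC(C)(C)c1ccc(SCc2ncnc3c2ncn3[C@@H]2O[C@H](CO)[C@@H](O)[C@H]2O)cc1` has not yet been measured in this assay. Set against compound 3, its change is 4-(tert-butyl)phenyl in place of 3,4-dichlorophenyl on a sulfur. Everything else in compound 3 is kept, and the sulfur that carries the saturated chain carbon simply exchanges one carbon-only six-membered aromatic ring for another. Among the compounds with values here, nothing among the measured compounds bears directly on this exchange, so the expectation rests on how much of compound 3 survives unchanged. The step in this assay is expected to be modest and towards a weaker inhibitor, estimated at a 2.2-fold higher number from compound 3 to compound 4 (0.35 log units; beyond the scatter). Compound 4 in this assay is accordingly estimated at 500 nM, with a range from 150 nM to 2000 nM.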

Compound 4, half-maximal inhibitory concentration: 331000 nM
For compound 4 the middle estimate is 660-fold (2.82 log units) below the measured one; measured number above the stated range.
By their numbers in this assay, from the lowest: compound 3; then compound 1; then compound 4; then compound 2.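

In this assay the group on the sulfur whose other neighbour is the saturated chain carbon proves far from interchangeable: 4-(tert-butyl)phenyl in place of 3,4-dichlorophenyl gives a 1500-fold higher number from compound 3 to compound 4 (3.17 log units; beyond the scatter) and this large step lies beyond the scatter. The loss appears even though both groups hold one six-membered aromatic ring of carbon only, with no hydrogen-bond donors or acceptors and no net charge on either side. This first single-place step in the series therefore shows that the exchange of one substituted ring for the other, with the rest of compound 3 kept, is enough to turn a strong inhibitor into a weak one, and no measurement in hand accounts for its size.

It remains open whether the loss follows from removing the two chlorines or from adding the tert-butyl group, as plain phenyl and rings carrying a single chlorine or a methyl group are not among the compounds shown. Also open, from the compounds shown here alone, is how an amine or a carboxylic acid on this ring, or an oxygen in place of the sulfur, would read in this assay on the same core.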